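Swapping a diol chain for a dimethylamino chain

The source may hold more compounds than are shown below. What is called first, only, known or untested is meant among the compounds shown, and "the series" means these compounds.

In an ADME assay on HepG2 2.2.15 cells (Homo sapiens) for cytotoxicity, read by MTT assay, with a stated time of 8 days (on this read-out lower numbers stand for higher toxicity in this test and higher numbers for lower toxicity in this test), compound 1 `N#Cc1ccc(Cn2nc(-c3cc(Cl)c(NCCO)nc3F)c3ccccc3c2=O)cc1` gives 32100 nM as a true reading. Compound 2 `COCCNc1nc(F)c(-c2nn(Cc3ccc(C#N)cc3)c(=O)c3ccccc23)cc1Cl` gives > 100000 nM as a limit of the assay and not a number. As far as these compounds go, compound 3 `N#Cc1ccc(Cn2nc(-c3cc(Cl)c(NC[C@H](O)CO)nc3F)c3ccccc3c2=O)cc1` gives > 100000 nM as a limit too, so its true place on the scale is unknown.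

The change from compound 3 to compound 4 `CN(C)CCNc1nc(F)c(-c2nn(Cc3ccc(C#N)cc3)c(=O)c3ccccc23)cc1Cl` is (dimethylamino)methyl in place of 1,2-dihydroxyethyl on a saturated chain carbon bound to a nitrogen on an aromatic ring and it puts (dimethylamino)methyl in place of 1,2-dihydroxyethyl on a saturated chain carbon bound to a nitrogen on an aromatic ring.

Changes on this same chain give an at least 3.1-fold higher number from compound 1 to compound 2 (0.49 log units; beyond the scatter) and also an at least 3.1-fold higher number from compound 1 to compound 3 (0.49 log units; beyond the scatter) while the third comparison is a step that the two limits leave unreadable from compound 2 to compound 3 and adds nothing on size.

Taking an at least 3.1-fold higher number from compound 1 to compound 3 (0.49 log units; beyond the scatter) as a guide to size, a modest fall back towards a readable number is expected, and the estimate is an at least 2.2-fold lower number from compound 3 to compound 4 (0.34 log units; beyond the scatter) for this swap. The estimate for compound 4 is 45000 nM with 13000 nM to 100000 nM as the expected range.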

Compound 4, half-maximal cytotoxic concentration: 9760 nM
Beside the measured number, compound 4's estimate is 4.6-fold (0.66 log units) above it; the measured number lies below the stated range.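

In this assay, dimethylamino in place of hydroxy gives a 3.3-fold lower number from compound 1 to compound 4 (0.52 log units; beyond the scatter) and is the first change shown on this chain to lower the number, which here means higher toxicity in this test. Both an at least 10-fold lower number from compound 2 to compound 4 (1.01 log units; beyond the scatter) and an at least 10-fold lower number from compound 3 to compound 4 (1.01 log units; beyond the scatter) are large steps whose true size stays open, because each starts from a limit of the assay: the limit of > 100000 nM in this assay, at which 2 of the 4 values shown sit.

The compounds shown leave open whether a primary amine or a morpholine on this chain, or a longer chain ending in dimethylamino, would lower the number as far.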